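The source may report more compounds than this note shows. Statements on the series, on what has been measured and on what is new or still open speak of the compounds shown alone.

Three of four compounds have so far been measured in a functional assay on OVCAR-5 cells (Homo sapiens) for cytotoxicity, read by sulforhodamine B assay, with a stated time of 48 h; on this read-out lower numbers stand for stronger inhibition of growth and higher numbers for weaker inhibition of growth. Compound 1 `Nc1nc(Cl)c2ncn(Cc3ccc(CCl)cc3)c2n1` gives 14800 nM, compound 2 `ClCc1cccc(Cn2cnc3c(Cl)nc(Cl)nc32)c1` gives 20400 nM, and compound 3 `ClCc1ccc(Cn2cnc3c(Cl)nc(Cl)nc32)cc1` gives 34700 nM, while compound 4 `Nc1nc(Cl)c2ncn(Cc3cccc(CCl)c3)c2n1` awaits measurement. Compound 2 and compound 3 have the same atoms joined differently; the difference between the two cores is not broken down here, and their values lie within the scatter of each other, as do those of compound 1 and compound 2. Compound 3 and compound 1 differ by amino in place of chloro on an aromatic carbon, which gave a 2.3-fold lower number from compound 3 to compound 1 (0.37 log units; beyond the scatter). Compound 2 and compound 4 differ by the same change, (amino in place of chloro on an aromatic carbon), on the other core. Because the measured step of a 2.3-fold lower number from compound 3 to compound 1 (0.37 log units; beyond the scatter) was modest but beyond the scatter, compound 4 is expected to show a similar step, a 2.3-fold lower number from compound 2 to compound 4 (0.36 log units; beyond the scatter), in this assay. The estimate for compound 4 is 9000 nM, expected to fall between 4500 nM and 18000 nM.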

Compound 4, concentration for total growth inhibition: 25100 nM
The estimate for compound 4 lay 2.8-fold (0.45 log units) below the measured number; measured number outside the range, above it.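

On the core of compound 2, amino in place of chloro on an aromatic carbon gave a 1.2-fold higher number from compound 2 to compound 4 (0.09 log units; within the scatter), so in this assay the change had no effect that can be told from the scatter on this core. The step therefore did not carry over between the two cores: the same change on two cores in this assay, a 2.3-fold lower number (0.37 log units; beyond the scatter) from compound 3 to compound 1 and a 1.2-fold higher number (0.09 log units; within the scatter) from compound 2 to compound 4, 2.9-fold (0.46 log units) apart, beyond the scatter of two such steps

This shows that, for this pair of cores, the step seen on one is no reliable guide to the other; it does not show why they differ, and two steps set no rule for the wider series. The compounds shown leave open what a methylamino group or a longer chain in place of the amino group would do in this assay, and whether the two cores would again part for such groups.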